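The source may hold more compounds than are shown below. What is called first, only, known or untested is meant among the compounds shown, and "the series" means these compounds.

Going by the values given here, compound 2, `CC/C(=C(/c1ccc(/C=C/C(=O)O)cc1)c1cc2cn[nH]c2cn1)c1ccccc1`, gives 442 nM in a functional assay on MCF7 cells (Homo sapiens) for cytotoxicity, read by CellTiter-Glo, with a stated time of 5 days (on this read-out higher numbers stand for weaker inhibition and lower numbers for stronger inhibition), the higher of the two numbers measured so far. Among the compounds with values here, compound 1, `CC/C(=C(/c1ccc(/C=C/C(=O)O)cc1)c1ccc2[nH]ncc2c1)c1ccccc1`, gives 7.2 nM in this assay, and the single step between them, a 61-fold higher number from compound 1 to compound 2 (1.79 log units; beyond the scatter), is the only measured step available. Compound 3, `CC/C(=C(/c1ccc(/C=C/C(=O)O)cc1)c1ccc2[nH]nc(C)c2c1)c1ccccc1`, has not been measured. It differs from compound 2 by a group of 10 heavy atoms (8 carbon, 2 nitrogen; one five-membered aromatic ring with 2 hetero atoms, one six-membered aromatic ring of carbon only) in place of a group of 9 heavy atoms (6 carbon, 3 nitrogen; one five-membered aromatic ring with 2 hetero atoms, one six-membered aromatic ring with 1 hetero atom), on a double-bonded chain carbon bound to an aromatic carbon and a double-bonded chain carbon. Within the data shown here, this change brings back the six-membered aromatic ring of carbon only that compound 1 carries, and adds a methyl on the five-membered ring, so the measured step from compound 1 to compound 2 bears on it directly, in reverse: removing the ring nitrogen is expected to lower the number by a large amount. Among the measured compounds shown here, no measured pair shows what the added methyl does, so that part is left open within the scatter. For compound 3 a large drop is therefore expected, a 37-fold lower number from compound 2 to compound 3 (1.57 log units; beyond the scatter), landing close to compound 1. The estimate for compound 3 in this assay is 12 nM, with a range from 3 nM to 50 nM.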

Compound 3, half-maximal inhibitory concentration: > 1000 nM
Compound 3: a limit, no number; the forecaster's own chance of this, stated with the estimate: 2%; middle value at least 83-fold (1.92 log units) from the limit.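

Going by these compounds alone, the methyl on the five-membered ring, which no earlier pair touched, turns out to matter most at this place: with 3-methyl-1H-indazol-5-yl in place of the unmethylated group of compound 1, the change of methyl for hydrogen on an aromatic carbon gives an at least 130-fold higher number from compound 1 to compound 3 (2.14 log units; beyond the scatter) in this assay. The six-membered aromatic ring of carbon only therefore does not secure the low number of compound 1 on its own; going back to that ring with the methyl added gives an at least 2.2-fold higher number from compound 2 to compound 3 (0.35 log units; beyond the scatter), so compound 3 ends up on the far side of compound 2 and not close to compound 1. Going by these compounds, the reading for compound 3 is a limit of the assay and not a number, so the full size of both steps stays unknown: the limit of > 1000 nM in this assay, at which 1 of the 3 values shown sits.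

The compounds shown hold only hydrogen or methyl on that aromatic carbon, so it remains open how a fluorine, a hydroxyl or a longer chain such as ethyl would read there. It also remains open what the same methyl would do on the group of compound 2, and nothing shown gives a reason for the effect of the methyl.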